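Working notes: swapping the group on the chain carbon

The compounds below may be only part of what the source reports. "The series", "measured", "known", "first", "only" and "open" are said of these compounds alone.

Measured compounds:
- compound 1, `Cc1cccc(Cn2c(CN3CCN(C(=O)c4ccc([N+](=O)[O-])cc4)CC3)nc3ccccc32)c1`: 24.3%
- compound 2, `Cc1cccc(Cn2c(CN3CCN(C(=O)c4ccc(C(C)C)cc4)CC3)nc3ccccc32)c1`: 67.6%
- compound 3, `O=C(C1CC1)N1CCN(Cc2nc3ccccc3n2Cc2ccccc2C(F)(F)F)CC1`: 56.3%

In an assay on isolated protein for inhibition of aldehyde dehydrogenase 1A1 (Homo sapiens), read by spectrophotometry, tested at 10 uM (on this read-out higher numbers stand for more inhibition at the one concentration tested (going by the name of the read-out) and lower numbers for less inhibition), compound 3 stands second highest of the three numbers; compound 2 lies above it beyond the scatter, and compound 1 lies well below it. Compound 4, `CC(C)=CCn1c(CN2CCN(C(=O)C3CC3)CC2)nc2ccccc21`, is not yet measured. It differs from compound 3 in one place: 2-methylprop-1-en-1-yl in place of 2-(trifluoromethyl)phenyl on a saturated chain carbon bound to an aromatic nitrogen. Going by the values given here, the only measured step, a number 43.3 percentage points higher from compound 1 to compound 2 (beyond the scatter), concerns the amide aryl group and not the chain carbon bound to the aromatic nitrogen, so no measured step bears on this change; all three measured compounds carry an aromatic ring there. The expectation for compound 4 is therefore uncertain, with a modest downward step of a number 16.3 percentage points lower from compound 3 to compound 4 (beyond the scatter) estimated. Compound 4 is expected to give 40%, within 15% to 65%.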

Compound 4, a percentage reported as inhibition, at one concentration (the size of the read-out at that concentration, not a potency): 74.3%
For compound 4 the middle estimate is 34.3 percentage points below the measured one; the measured number lies above the stated range.
By their numbers in this assay, from the lowest: compound 1; then compound 3; then compounds 2 and 4 (each within the scatter of the next).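

In this assay, an aromatic ring on this saturated chain carbon bound to an aromatic nitrogen is not required for inhibition: a number 18 percentage points higher from compound 3 to compound 4 (beyond the scatter) comes with 2-methylprop-1-en-1-yl in place of 2-(trifluoromethyl)phenyl. The entering group has no ring and 4 heavy atoms, against 10 heavy atoms in the group that leaves. No available evidence explains the higher number.

Whether the double bond contributes remains open, since the saturated 3-methylbutyl group is not among the compounds shown. On these data alone, the effect of an amine or a carboxylic acid at the end of this chain also remains open.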